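Swapping the aryl group on the triazole nitrogen

This account rests on a few compounds, and the source may have more. Where it says the series, first, only, none or still open, it means among the compounds named here.

Compound 2 `O=C(NO)c1ccc(NCc2nc(-c3ccccc3)nn2-c2cccc(Cl)c2)cc1` gives 62.3% in an assay on Sf9 cells for inhibition of protein deacetylase HDAC6 (Homo sapiens), read by fluorescence, with a stated time of 40 min, tested at 100 nM; a higher number here means more inhibition at the concentration tested (going by the name of the read-out), a lower number less inhibition. Its number is the highest of the three shown, though compound 1 `Cc1ccc(-c2nc(CNc3ccc(C(=O)NO)cc3)n(-c3ccccc3)n2)cc1`, with 62.2%, stands within the usual scatter of it, while compound 3 `Nc1ccccc1NC(=O)c1ccc(NCc2nc(-c3ccccc3)nn2-c2ccccc2)cc1`, with 5%, lies far beyond it. Compound 4 `O=C(NO)c1ccc(NCc2nc(-c3ccccc3)nn2-c2ccc(C(F)(F)F)cc2)cc1` is not yet measured; it differs from compound 2 by 4-(trifluoromethyl)phenyl in place of 3-chlorophenyl on an aromatic nitrogen. Within the data shown here, no measured pair shows this kind of change, so its size is unknown; the step from compound 2 to compound 4 is expected to be small, within the scatter, with no clear direction. The expected step is a number 4.3 percentage points lower from compound 2 to compound 4 (within the scatter). Compound 4 is therefore estimated at 58%, with a range from 40% to 75%.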

Compound 4, a percentage reported as inhibition, at one concentration (the size of the read-out at that concentration, not a potency): 38.9%
The estimate for compound 4 lay 19.1 percentage points above the measured number; the measured number lies below the stated range.
By their numbers in this assay, from the lowest: compound 3; then compound 4; then compounds 1 and 2 (each within the scatter of the next).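

In this assay the change to 4-(trifluoromethyl)phenyl brings a number 23.4 percentage points lower from compound 2 to compound 4 (beyond the scatter) and so shows that the number responds to the aryl group on this aromatic nitrogen. The named groups differ in both the substituent and its ring position, and this single step cannot separate the two. No measurement shown explains the drop.

Still open, from the compounds shown here alone, is whether the trifluoromethyl group or its ring position accounts for the step. Going by these compounds, how a 4-chlorophenyl group or a phenyl ring bearing a carboxylic acid would compare on this nitrogen also remains open.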